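The source may hold more compounds than are shown below. What is called first, only, known or untested is meant among the compounds shown, and "the series" means these compounds.

Measured so far:
Compound 1 `O=C(O)CCn1c(=O)oc2cc(OCC3CCC3)c(Cl)cc21`: 25.1 nM
Compound 2 `COc1cc2oc(=O)n(CCC(=O)O)c2cc1Cl`: 12.6 nM

In an assay for inhibition of kynurenine 3-monooxygenase (Homo sapiens), read by mass spectrometry, with a stated time of 1 h (a higher number here means a weaker inhibitor, a lower number a stronger inhibitor), compound 2 and compound 1 lie within the scatter of each other, as the step of a 2.0-fold lower number from compound 1 to compound 2 (0.30 log units; within the scatter) shows, so neither can be ranked above the other. Compound 3 `C[C@@H](Oc1cc2oc(=O)n(CCC(=O)O)c2cc1Cl)c1ncco1` is compound 2 with one change: a group of 7 heavy atoms (5 carbon, 1 nitrogen, 1 oxygen; one five-membered aromatic ring with 2 hetero atoms) in place of one carbon atom, on an oxygen on an aromatic ring. Among the compounds with values here, the only measured step that bears on this position is a 2.0-fold lower number from compound 1 to compound 2 (0.30 log units; within the scatter), where a cyclobutyl group in place of hydrogen on that oxygen left the number within the scatter. A larger group on the same oxygen is therefore expected to give no step beyond the scatter, a 1.2-fold higher number from compound 2 to compound 3 (0.08 log units; within the scatter). Compound 3 is estimated at 15 nM, with a range of 4 nM to 60 nM.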

Compound 3, half-maximal inhibitory concentration: 3.16 nM
For compound 3 the middle estimate is 4.7-fold (0.68 log units) above the measured one; measured number below the stated range.
By their numbers in this assay, from the lowest: compound 3; then compounds 2 and 1 (each within the scatter of the next).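

In this assay, within the data shown here, the oxygen on an aromatic ring does more than tolerate a larger group: a 4.0-fold lower number from compound 2 to compound 3 (0.60 log units; beyond the scatter) is the first step at this position beyond the scatter. The same group also improves on cyclobutyl, with a 7.9-fold lower number from compound 1 to compound 3 (0.90 log units; beyond the scatter), so the gain does not depend on which of the two earlier compounds serves as the reference. No measurement at hand accounts for this gain. Still open, from the compounds shown here alone, is how much of it belongs to the five-membered aromatic ring and how much to the defined stereocentre, and whether a phenyl ring or an amine on the same oxygen would match it.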